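Capping a Ring Nitrogen in a Sulfonyl Hydroxamate Series

The compounds below may be only part of what the source reports. "The series", "measured", "known", "first", "only" and "open" are said of these compounds alone.

Compound 1 `O=C(NO)[C@H]1CCCCN1S(=O)(=O)N1CC=C(c2ccc(F)cc2)CC1` carries a hydroxycarbamoyl group on a six-membered ring. In a functional assay on MONO-MAC-6 cells (Homo sapiens) for inhibition (a lower number here means a stronger inhibitor, a higher number a weaker inhibitor), compound 1 gives 300 nM. Compound 2 `O=C(NO)[C@H]1CNCCN1S(=O)(=O)N1CC=C(c2ccc(F)cc2)CC1` has a second nitrogen in that ring, and in this assay compound 2 gives 3560 nM, the highest of the two numbers shown and beyond the scatter from compound 1. Compound 3 `CN(C)C(=O)N1CCN(S(=O)(=O)N2CC=C(c3ccc(F)cc3)CC2)[C@@H](C(=O)NO)C1` differs from compound 2 by dimethylcarbamoyl in place of hydrogen on an amine nitrogen in a ring. Going by the values given here, no such step has been measured, so the expectation rests on compound 1 standing at 300 nM. The step of a 7.1-fold lower number from compound 2 to compound 3 (0.85 log units; beyond the scatter) is expected to be a lowering beyond the scatter. For compound 3 the estimate is 500 nM, within a range from 150 nM to 2500 nM.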

Compound 3, half-maximal inhibitory concentration: 200 nM
Estimate against measurement, compound 3: 2.5-fold (0.40 log units) above; low and high end bracket the measured number.
By their numbers in this assay, from the lowest: compounds 3 and 1 (each within the scatter of the next); then compound 2.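

In this assay the ring amine nitrogen of compound 2 proves open to substitution: dimethylcarbamoyl in place of hydrogen on that nitrogen gives an 18-fold lower number from compound 2 to compound 3 (1.25 log units; beyond the scatter) and counts as a large step. Going by these compounds alone, this position, two ring bonds from the ring atom that bears the hydroxycarbamoyl group, therefore accepts a group as large as dimethylcarbamoyl, something the earlier compounds could not show. Nothing available explains the drop. Going by these compounds, whether the whole group is needed stays open: an acetyl, a methyl or a methanesulfonyl group on the same nitrogen would test this.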